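The compounds below may be only part of what the source reports. "The series", "measured", "known", "first", "only" and "open" are said of these compounds alone.

Measured so far:
Compound 1 `COc1ccc2c(c1)OC(c1cc(OC)c(OC)c(OC)c1)C(C(=O)N1CCCCC1)=C2` gives > 50000 nM in a functional assay for inhibition of nuclear factor NF-kappa-B complex (Homo sapiens); on this read-out lower numbers stand for stronger inhibition and higher numbers for weaker inhibition.
Compound 2 `COc1ccc2c(c1)OC(c1cc(OC)c(OC)c(OC)c1)C(C=O)=C2` gives 13500 nM.

For compound 1 this value is only a limit of the assay, not a number (the limit of > 50000 nM in this assay, at which 1 of the 2 values shown sits). Compound 3 `COc1ccc2c(c1)OC(c1cc(OC)c(OC)c(OC)c1)C(C(N)=O)=C2` has not been measured; (amino in place of piperidin-1-yl on a carbonyl carbon). Within the data shown here, the one measured step at this carbonyl carbon, an at least 3.7-fold lower number from compound 1 to compound 2 (0.56 log units; beyond the scatter), also removed piperidin-1-yl and gave a lower number, so removing it again is expected to move the same way, an estimated step of an at least 1.6-fold lower number from compound 1 to compound 3 (0.22 log units; that floor lies within the scatter). Compound 3 is therefore expected near 30000 nM, estimated between 8000 nM and 100000 nM.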

Compound 3, half-maximal inhibitory concentration: > 50000 nM
Compound 3 gave a limit, no number; the forecaster's own chance of this, stated with the estimate: 40%; middle value at least 1.6-fold (0.22 log units) away from the limit.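

In this assay compound 3 gives > 50000 nM as a limit of the assay and not a number. Amino in place of hydrogen on this carbonyl carbon gives an at least 3.7-fold higher number from compound 2 to compound 3 (0.56 log units; beyond the scatter) so losing piperidin-1-yl does not by itself bring the lower number. The step between the two amides cannot be read, because both compounds stop at the same limit: the limit of > 50000 nM in this assay, at which 2 of the 3 values shown sit.

Still open, on these data alone, is what a methyl or a hydroxyl on this carbonyl carbon, giving a ketone or a carboxylic acid, would do. Also open, as far as these compounds go, is where compound 1 and compound 3 truly lie, since neither has a number.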